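The source may hold more compounds than are shown below. What is called first, only, known or untested is meant among the compounds shown, and "the series" means these compounds.

Compound 1 `CCOc1ccc(NC(=O)c2cccc(/C=C3\CC(=O)N(Cc4ccccc4)C3=O)c2)cc1` gives in an ADME assay on NCM460 cells (Homo sapiens) for cytotoxicity, read by MTT assay, with a stated time of 72 h; a higher number here means a weaker inhibitor, a lower number a stronger inhibitor > 100000 nM, a limit of the assay rather than a number.
Compound 2 `COc1ccc(NC(=O)c2cccc(/C=C3\CC(=O)N(c4ccccc4)C3=O)c2)cc1` gives in this assay > 100000 nM, again a limit.
Compound 3 `COc1ccc(NC(=O)c2cccc(/C=C3\CC(=O)N(c4ccc(C)cc4)C3=O)c2)cc1` gives in this assay > 100000 nM, also a limit.

Compound 2 thus stands only at a limit in this assay, and the same is true of everything around it: the limit of > 100000 nM in this assay, at which 3 of the 3 values shown sit. Among the compounds with values here, the single one-point change among the measured compounds, a step that the two limits leave unreadable from compound 2 to compound 3, is a methyl in place of hydrogen on an aromatic carbon. Both ends of that step are limits, and its size cannot be read.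

Compound 4 `O=C(Nc1ccccc1)c1cccc(/C=C2\CC(=O)N(c3ccccc3)C2=O)c1` is yet to be measured in this assay. It differs from compound 2 by hydrogen in place of methoxy on an aromatic carbon.

Within the data shown here, no measured step bears directly on this change, and the one step recorded is unreadable, so no shift beyond the scatter is expected in this assay; the expected step that the limit leaves unreadable from compound 2 to compound 4 is therefore essentially nil. Compound 4 is expected to give in this assay about 150000 nM, within a range from 50000 nM to 500000 nM, most likely again reported as a limit.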

Compound 4, half-maximal inhibitory concentration: > 100000 nM
Compound 4: a limit, no number (the forecaster's own chance of this, stated with the estimate: 85%); the middle value is on the limit's open side.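

No new step can be read from compound 2 to compound 4, as each result is a limit and not a number: the limit of > 100000 nM in this assay, at which 4 of the 4 values shown sit.

The compounds shown leave open whether hydrogen in place of methoxy changes the result in this assay at all, and what any of their actual values is.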